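Sulfonyl for carbamoyl at the amine nitrogen of compound 2

The source may hold more compounds than are shown below. What is called first, only, known or untested is meant among the compounds shown, and "the series" means these compounds.

Two compounds of the series have numbers in a functional assay on Ehrlich cells (Mus musculus) for cytotoxicity, read by trypan blue exclusion, with a stated time of 2 h, tested at 25 ug/mL; a higher number here means a stronger effect of the compound at the concentration tested, a lower number a weaker effect. Compound 1 `N#CC1=C(NC(=S)Nc2ccccc2)N(c2ccc(S(N)(=O)=O)cc2)C2=C(C(=O)CCC2)C1c1ccc(Cl)cc1Cl` gives 50% in this assay. Among the measured compounds shown here, compound 2 `N#CC1=C(NC(N)=O)N(c2ccc(S(N)(=O)=O)cc2)C2=C(C(=O)CCC2)C1c1ccc(Cl)cc1Cl` gives 35% in this assay, the lower of the two numbers, and the step of a number 15 percentage points lower from compound 1 to compound 2 (beyond the scatter) is the only step measured so far; it accompanies the exchange of a group of nine heavy atoms carrying a six-membered aromatic ring of carbon only for a group of three heavy atoms without a ring, on an amine nitrogen.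

Compound 3 `N#CC1=C(NS(=O)(=O)c2ccc(Br)cc2)N(c2ccc(S(N)(=O)=O)cc2)C2=C(C(=O)CCC2)C1c1ccc(Cl)cc1Cl` has not been measured in this assay. Relative to compound 2 the change is (4-bromophenyl)sulfonyl in place of carbamoyl on an amine nitrogen. For the measured compounds named here, the one measured step bears on it only loosely: it shows that losing a ring-bearing group on this amine nitrogen went with a lower number, and compound 3 brings a ring-bearing group back, though of a different kind. An increase beyond the scatter is therefore expected, roughly undoing the earlier drop, with wide uncertainty. The estimated step is a number 13 percentage points higher from compound 2 to compound 3 (beyond the scatter). For compound 3 the expected value in this assay is 48%, within a range from 30% to 66%.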

Compound 3, a percentage reported as activity, at one concentration (the size of the read-out at that concentration, not a potency): 90%
For compound 3 the middle estimate is 42 percentage points below the measured one; the measured number lies above the stated range.
By their numbers in this assay, from the lowest: compound 2; then compound 1; then compound 3.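

In this assay, (4-bromophenyl)sulfonyl in place of carbamoyl on the amine nitrogen goes with a number 55 percentage points higher from compound 2 to compound 3 (beyond the scatter), so this place in the series can carry a much higher number than the earlier pair showed. The presence of a ring on the entering group does not by itself set the number: compound 1 also carries a six-membered aromatic ring of carbon only at this place, yet the read-out still shows a number 40 percentage points higher from compound 1 to compound 3 (beyond the scatter) and so separates two ring-bearing groups of similar heavy-atom count. Nothing shown explains the size of either step.

The compounds shown do not separate the contribution of the sulfonyl link from that of the bromine: a phenylsulfonyl group without bromine and a methylsulfonyl group with no ring would each pull these two apart. Since the read-out comes from one concentration, it tells only of a stronger or weaker effect at that concentration and leaves open how the order of compound 1, compound 2 and compound 3 would look at any other concentration.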